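Exchanging a phenyl group at the limit of measurement

The compounds below may be only part of what the source reports. "The series", "measured", "known", "first", "only" and "open" are said of these compounds alone.

- compound 1 `O=S(=O)(/C=C/c1ccc(C(F)(F)F)cc1F)Cc1ccc(Nc2ncnc3ccccc23)cc1`: 100000 nM
- compound 2 `O=S(=O)(/C=C/c1ccc(Cl)cc1Cl)Cc1ccc(Nc2ncnc3cc(Cl)ccc23)cc1`: > 100000 nM

In a functional assay on OVCAR-8 cells (Homo sapiens) (on this read-out higher numbers stand for weaker inhibition of growth and lower numbers for stronger inhibition of growth), compound 1 gives 100000 nM. Compound 2 stands at > 100000 nM, and this is a limit of this assay and not a number.

Compound 3 `O=S(=O)(/C=C/c1ccc(C(F)(F)F)cc1F)Cc1ccc(Nc2ncnc3cc(Cl)ccc23)cc1` is reached from compound 2 by a single exchange: 2-fluoro-4-(trifluoromethyl)phenyl in place of 2,4-dichlorophenyl on a double-bonded chain carbon bound to a double-bonded chain carbon. Here 2-fluoro-4-(trifluoromethyl)phenyl comes in place of 2,4-dichlorophenyl on a double-bonded chain carbon bound to a double-bonded chain carbon.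

Among the compounds with values here, no step between measured compounds is available to size this exchange. The expectation rests on compound 1, which carries the entering group and gives 100000 nM. No change beyond the scatter is expected in this assay, in either direction. The expected step is a number no higher from compound 2 to compound 3 (the limit leaves the size open). For compound 3 the estimated value is 100000 nM, with an expected range from 40000 nM to 150000 nM.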

Compound 3, concentration for 50% growth inhibition: > 100000 nM
Compound 3 ended at the assay's limit (the forecaster's own chance of this, stated with the estimate: 65%); the middle value sits exactly at the limit.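

Within the data shown here, with compound 3, the exchange of 2,4-dichlorophenyl for 2-fluoro-4-(trifluoromethyl)phenyl on a double-bonded chain carbon bound to a double-bonded chain carbon is seen for the first time between two compounds that both carry the extra chloro. Chloro in place of hydrogen on an aromatic carbon gives a number no lower from compound 1 to compound 3 (the limit leaves the size open) in this assay and the entering group does not bring compound 3 off the limit, so compound 1 remains the only one of the three with a number. Neither this exchange nor chloro in place of hydrogen on an aromatic carbon can be sized, because the values lie at the limit: the limit of > 100000 nM in this assay, at which 2 of the 3 values shown sit.

As far as these compounds go, whether the two phenyl groups differ at all in this assay stays open. So does what an amine or a carboxylic acid in place of the phenyl group on that chain carbon would give.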